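What One Added Methyl May Do to Cytotoxicity

The source may hold more compounds than are shown below. What is called first, only, known or untested is meant among the compounds shown, and "the series" means these compounds.

Measured so far in a functional assay on HeLa cells (Homo sapiens) for cytotoxicity, with a stated time of 3 days; on this read-out higher numbers stand for weaker inhibition and lower numbers for stronger inhibition (both values below)
- Compound 1 (`Clc1ccc(-c2cc(-c3ccsc3)nc(-c3cccs3)c2)o1`) gives 43700 nM
- Compound 2 (`Cc1ccsc1-c1cc(-c2ccco2)cc(-c2cccs2)n1`) gives 17900 nM

Compound 2 holds the lower of the two numbers, and compound 1 (43700 nM) lies higher by a gap beyond the scatter. Compound 3 (`Cc1ccsc1-c1cc(-c2ccco2)cc(-c2sccc2C)n1`) has methyl in place of hydrogen on an aromatic carbon of compound 2, so thiophen-2-yl becomes 3-methylthiophen-2-yl (methyl in place of hydrogen on an aromatic carbon). For the measured compounds named here, no measured pair shows this change, so the expectation is loose: a small shift towards lower numbers in this assay, probably none beyond the scatter. The expected step (a 1.3-fold lower number from compound 2 to compound 3 (0.11 log units; within the scatter)) is only an estimate. For compound 3 the estimated value is 14000 nM (expected range 5000 nM to 40000 nM).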

Compound 3, half-maximal inhibitory concentration: 35800 nM
Compound 3: the middle estimate sits 2.6-fold (0.41 log units) below what was measured, within the range that was stated.
By their numbers in this assay, from the lowest: compounds 2, 3 and 1 (each within the scatter of the next, the first and the last beyond it).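

For the compounds shown here, compound 2 and compound 3 are the first pair here that differs in one place, so they give the first direct reading of this change. In this assay the swap of thiophen-2-yl for 3-methylthiophen-2-yl gives a 2.0-fold higher number from compound 2 to compound 3 (0.30 log units; within the scatter) and so shows that a methyl at this position, next to the ring atom that bears a large group, produces no shift that stands clear of the scatter. Nothing at hand speaks to what lies behind this step.

The compounds shown leave open whether a different group at this position, such as an amine, a carboxylic acid or a longer chain, would move the number beyond the scatter.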